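Notes on swapping the pyridinyl group for benzyloxy

The compounds below may be only part of what the source reports. "The series", "measured", "known", "first", "only" and "open" are said of these compounds alone.

Measured so far in an ADME assay on microsomes from liver (Rattus norvegicus) for metabolic stability (on this read-out lower numbers stand for a shorter-lived compound and higher numbers for a longer-lived compound), for the series:
Compound 1 `COc1cc(OCc2cccc(-c3ccc(OC)nc3)c2)c2cc(-c3cn4nc(OC)sc4n3)oc2c1` gives 0.633 h
Compound 2 `COc1cc(OCc2csc(-c3ccc(C(N)=O)cc3)n2)c2cc(-c3cn4nc(OC)sc4n3)oc2c1` gives 0.4 h
Compound 3 `COc1cc(OCc2csc(-c3ccc(C(=O)O)cc3)n2)c2cc(-c3cn4nc(OC)sc4n3)oc2c1` gives > 2 h (a limit, not a number)

Compound 1 at 0.633 h and compound 2 at 0.4 h lie within the scatter of each other. Compound 3 gives only a limit of the assay, > 2 h and no number.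

Compound 4 `COc1cc(OCc2cccc(OCc3ccccc3)c2)c2cc(-c3cn4nc(OC)sc4n3)oc2c1` carries benzyloxy in place of 6-methoxypyridin-3-yl on an aromatic carbon with the rest of compound 1 unchanged.

Within the data shown here, the one measured step, an at least 5.0-fold higher number from compound 2 to compound 3 (0.69 log units; beyond the scatter) with hydroxy in place of amino on a carbonyl carbon, lies beyond the scatter. It changes a different group, however, so it bears only weakly on this swap. Among the measured compounds shown here, no measured step covers the group exchanged here, which leaves compound 1 at 0.633 h as the reference. The expected step is a 1.4-fold lower number from compound 1 to compound 4 (0.15 log units; within the scatter) and is estimated to stay within the scatter. Compound 4 is expected to give 0.45 h as the estimate in this assay with an expected range from 0.2 h to 1 h for the coming measurement.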

Compound 4, half-life: 0.333 h
For compound 4 the middle estimate is 1.4-fold (0.13 log units) above the measured one; the measured number falls inside the stated range.
By their numbers in this assay, from the lowest: compounds 4, 2 and 1 (each within the scatter of the next). At a limit, above all of these: compound 3.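

In this assay, among these compounds, the exchange of the two groups gives a 1.9-fold lower number from compound 1 to compound 4 (0.28 log units; within the scatter), the first measured step at this place on an aromatic carbon, meta to a large group. A ring of carbon only, attached through the oxygen of benzyloxy, therefore stands in for 6-methoxypyridin-3-yl with a change no greater than repeat measurements would give, so on this read-out the two groups cannot be told apart. Nothing measured here gives a cause for the step.

As far as these compounds go, compound 3 gives > 2 h, a limit and not a number, and whether a carboxylic acid would act the same way on compound 4 stays open. Also open, from the compounds shown here alone, is what an amine or a nitrile would give at this place.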